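Thiazole for Imidazole on a Sulfonyl Sulfur

The compounds below may be only part of what the source reports. "The series", "measured", "known", "first", "only" and "open" are said of these compounds alone.

Measured compounds:
compound 1 `CC1CCN(C2CCN(S(=O)(=O)c3cn(C)cn3)CC2)CC1` — > 5000 nM
compound 2 `CC1CCN(C2CCN(S(=O)(=O)c3ccc(C(C)(C)C)cc3)CC2)CC1` — > 5000 nM

In a functional assay on DLD-1 cells (Homo sapiens) for antiproliferative activity, read by CellTiter-Glo, with a stated time of 72 h (on this read-out lower numbers stand for stronger inhibition and higher numbers for weaker inhibition), compound 1 gives only a limit, > 5000 nM. Compound 2 likewise returns only a limit, > 5000 nM. Compound 1 therefore stands at the limit of > 5000 nM in this assay, at which 2 of the 2 values shown sit, and no finished number separates the two compounds. Compound 3 `CC1CCN(C2CCN(S(=O)(=O)c3cnc(Cl)s3)CC2)CC1` differs from compound 1 by 2-chloro-1,3-thiazol-5-yl in place of 1-methyl-1H-imidazol-4-yl on a sulfonyl sulfur. Among the compounds with values here, no step between measured compounds has been resolved here, so the expected step that the limit leaves unreadable from compound 1 to compound 3 in this assay is taken as none beyond the scatter. Compound 3 is accordingly estimated at 8000 nM, within 3000 nM to 25000 nM, and most likely again reported only as a limit.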

Compound 3, half-maximal inhibitory concentration: 1800 nM
Compound 3: middle estimate off by 4.4-fold (0.65 log units), on the high side; the measured number lies below the stated range.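

In this assay, the group on the sulfonyl sulfur proves able to move the read-out: 2-chloro-1,3-thiazol-5-yl in place of 1-methyl-1H-imidazol-4-yl gives an at least 2.7-fold lower number from compound 1 to compound 3 (0.44 log units; beyond the scatter). Compound 3 holds the only finished number among the compounds shown, so this position is no longer silent. The true size of the step stays unknown because compound 1 gives only a limit: the limit of > 5000 nM in this assay, at which 2 of the 3 values shown sit.

The compounds shown leave open whether the chlorine or the thiazole ring itself carries the step. On these data alone, how a methyl group in place of the chlorine, or a thiophene ring, would read also remains open.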